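From bromopropoxy to hydroxyethoxy: one cytotoxicity step

The compounds below may be only part of what the source reports. "The series", "measured", "known", "first", "only" and "open" are said of these compounds alone.

Values measured in an ADME assay on L929 cells (Mus musculus) for cytotoxicity, read by resazurin assay, with a stated time of 48 h; on this read-out higher numbers stand for lower toxicity in this test and lower numbers for higher toxicity in this test:
Compound 1 `O=C(O)CCCn1c2ccc([N+](=O)[O-])cc2c(=O)n1Cc1ccccc1`: > 256000 nM, a limit
Compound 2 `CN(C)C(=O)CCCn1c2ccc([N+](=O)[O-])cc2c(=O)n1Cc1ccccc1`: > 256000 nM, a limit
Compound 3 `O=[N+]([O-])c1ccc2nn(Cc3ccccc3)c(OCCCBr)c2c1`: 59000 nM

Going by the values given here, compound 3 holds the only actual number in the set, at 59000 nM. Compound 1 and compound 2 both stand at the limit of > 256000 nM in this assay, at which 2 of the 3 values shown sit. Compound 4 `O=[N+]([O-])c1ccc2nn(Cc3ccccc3)c(OCCO)c2c1` differs from compound 3 by hydroxy in place of bromomethyl on a saturated chain carbon, two bonds along the chain from an oxygen on an aromatic ring, which turns 3-bromopropoxy into 2-hydroxyethoxy. Among the compounds with values here, no measured step shows this change. Within the data shown here, the single step available, a step that the two limits leave unreadable from compound 1 to compound 2, concerns another group and has no readable size, so it sets no size here. Compound 4 loses the bromine, which compound 1 and compound 2 also lack, so a move toward higher numbers in this assay, meaning lower toxicity, is expected. The estimated step is a 2.7-fold higher number from compound 3 to compound 4 (0.43 log units; beyond the scatter). For compound 4 the estimated value is 160000 nM, with an expected range from 70000 nM to 256000 nM.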

Compound 4, concentration lethal to 50% of the cells: > 256000 nM
Compound 4 gave a limit, no number (the forecaster's own chance of this, stated with the estimate: 50%); at least 1.6-fold (0.20 log units) between middle value and limit.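

In this assay, the change from 3-bromopropoxy to 2-hydroxyethoxy gives an at least 4.3-fold higher number from compound 3 to compound 4 (0.63 log units; beyond the scatter). Going by these compounds alone, this is the first step in the set with a readable lower bound, as the step between the two earlier limits cannot be read. Compound 1, compound 2 and compound 4, all without bromine, each give a limit and not a number: the limit of > 256000 nM in this assay, at which 3 of the 4 values shown sit.

As far as these compounds go, compound 4 gives only a limit, so the full size of the step stays open. The compounds shown also leave open whether losing the bromine or shortening the chain carries the step, and how a 3-hydroxypropoxy chain or a terminal amine would read.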